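The source may report more compounds than this note shows. Statements on the series, on what has been measured and on what is new or still open speak of the compounds shown alone.

Measured so far: compound 1 `CCCNC(=O)/N=C(\N)NCCCc1sc(N)nc1C`, 105 nM; compound 2 `Cc1nc(N)sc1CCCN/C(N)=N/C(=O)NC(c1ccccc1)c1ccccc1`, 43.7 nM.

In an assay on membranes from Sf9 cells for displacement of a labelled ligand from histamine H2 receptor (Homo sapiens), read by scintillation counting, with a stated time of 60 min (on this read-out lower numbers stand for stronger inhibition and higher numbers for weaker inhibition), compound 1 gives 105 nM, the higher of the two numbers; compound 2 gives 43.7 nM, a gap beyond the usual scatter. Compound 3 `Cc1nc(N)sc1CCCN/C(N)=N/C(=O)NCC(C)CC1CCCCC1` has yet to be measured. It differs from compound 1 by cyclohexylmethyl in place of hydrogen on a saturated chain carbon bound to two saturated chain carbons. Within the data shown here, no pair of measured compounds isolates this change. A modest move toward a lower number is expected, since compound 2 with its larger group gives 43.7 nM. The expected step from compound 1 to compound 3 is a 1.9-fold lower number from compound 1 to compound 3 (0.28 log units; within the scatter). Compound 3 is estimated at 55 nM, within 20 nM to 150 nM.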

Compound 3, inhibition constant: 70.8 nM
Compound 3: the middle estimate sits 1.3-fold (0.11 log units) below what was measured, within the range that was stated.
By their numbers in this assay, from the lowest: compounds 2, 3 and 1 (each within the scatter of the next, the first and the last beyond it).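

In this assay, among these compounds, cyclohexylmethyl in place of hydrogen on a saturated chain carbon bound to two saturated chain carbons gives a 1.5-fold lower number from compound 1 to compound 3 (0.17 log units; within the scatter) as the first reading of a single change at this position. This position therefore takes a group of 7 heavy atoms with one six-membered non-aromatic ring, with no change beyond the scatter. Nothing measured here accounts for this result. As far as these compounds go, whether a carboxylic acid or a hydroxyl group on the same carbon would read differently remains open.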